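A few compounds are considered here, and "the series" means these few. Any claim that something is new, unique, unknown or untested is made for them only; others in the source may bear on it.

Compound 1 `N#Cc1ccc(N2CCc3cc(-c4cnc5ccccc5c4)ccc3C2)cc1C(F)(F)F` gives > 30000 nM in a functional assay on VCaP cells (Homo sapiens) for antiproliferative activity, read by CCK-8 assay, with a stated time of 6 days (a lower number here means a stronger inhibitor, a higher number a weaker inhibitor), which is a limit of the assay rather than a number.
Compound 2 `CCN(c1ccc(C#N)c(Cl)c1)c1cc(-c2cncnc2)ccc1C` gives 3920 nM in this assay.
Compound 3 `CCN(c1cccc(-n2ccnc2)c1)c1ccc(C#N)c(C(F)(F)F)c1` gives > 30000 nM in this assay, again a limit and not a number.

Only a limit is known for compound 1. Among the three measured compounds, (the limit of > 30000 nM in this assay, at which 2 of the 3 values shown sit), so compound 1 cannot be placed in order against compound 3, and only compound 2 gives a number at all. Going by the values given here, these three share no single-point change between them, so no measured step is available to guide what follows.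

Compound 4 `N#Cc1ccc(N2CCc3cc(-c4ccncc4)ccc3C2)cc1C(F)(F)F` differs from compound 1 in one place: pyridin-4-yl in place of quinolin-3-yl on an aromatic carbon. The quinolin-3-yl, with its two fused aromatic rings, leaves and the smaller pyridin-4-yl enters at the same aromatic carbon of the shared core.

Among the compounds with values here, with no measured step to draw on and compound 1 already sitting at the limit, no change beyond the usual scatter is expected from compound 1 to compound 4 in this assay. Compound 4 is estimated at 30000 nM, with a range from 8000 nM to 100000 nM. The step from compound 1 to compound 4 is expected to be a number no higher from compound 1 to compound 4 (the limit leaves the size open), most likely with compound 4 also reported only as a limit.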

Compound 4, half-maximal inhibitory concentration: 3500 nM
The estimate for compound 4 lay 8.6-fold (0.93 log units) above the measured number; measured number outside the range, below it.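

Placing pyridin-4-yl in place of quinolin-3-yl on the same aromatic carbon of the shared core gives an at least 8.5-fold lower number from compound 1 to compound 4 (0.93 log units; beyond the scatter) in this assay and provides the first measured step among these compounds. This position therefore responds to the group it carries: the lower number comes with the loss of the fused ring of carbon only, while a six-membered aromatic ring with one hetero atom remains. From the compounds shown here alone, the full size of the step stays unknown, since compound 1 is held at a limit of the assay and not a number: the limit of > 30000 nM in this assay, at which 2 of the 4 values shown sit.

The compounds shown leave open whether the lower number belongs to pyridin-4-yl itself or simply follows from removing the fused ring. A plain phenyl ring, or a pyridine ring carrying an amine, at this carbon would help separate the two.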